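Amide replacement on the carbonyl carbon: compound 4

The source may hold more compounds than are shown below. What is called first, only, known or untested is meant among the compounds shown, and "the series" means these compounds.

In a functional assay on B16-F10 cells (Mus musculus) for inhibition, read by MTT assay, with a stated time of 48 h (on this read-out lower numbers stand for stronger inhibition and higher numbers for weaker inhibition), compound 1 `CCC(C)NC(=O)/C=C/c1c(/C=C/c2ccc(OC)cc2)cc(OC)cc1OC` gives 4380 nM, the lowest of the three numbers at hand. Compound 3 `COc1ccc(/C=C/c2cc(OC)cc(OC)c2/C=C/C(=O)N(CC(C)C)CC(C)C)cc1` gives 4850 nM, and compound 2 `COc1ccc(/C=C/c2cc(OC)cc(OC)c2/C=C/C(=O)N2CCC(c3ccccc3)CC2)cc1` gives 9180 nM. The step of a 1.1-fold higher number from compound 1 to compound 3 (0.04 log units; within the scatter) lies within the scatter, while the step of a 2.1-fold higher number from compound 1 to compound 2 (0.32 log units; beyond the scatter) lies beyond it; the step of a 1.9-fold lower number from compound 2 to compound 3 (0.28 log units; within the scatter) again lies within the scatter.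

Compound 4 `COc1ccc(/C=C/c2cc(OC)cc(OC)c2/C=C/C(=O)N2CCN(C)CC2)cc1` differs from compound 1 in one place: 4-methylpiperazin-1-yl in place of (sec-butyl)amino on a carbonyl carbon. The two measured steps from compound 1 bear on this change, since both replace (sec-butyl)amino on the carbonyl carbon with a group lacking a hydrogen-bond donor. The acyclic diisobutylamino gave no step beyond the scatter, whereas the ring-bearing 4-phenylpiperidin-1-yl gave a modest higher number. The entering 4-methylpiperazin-1-yl carries a ring, so a small rise in this assay is the more likely outcome, though it may also stay within the scatter.

Compound 4 is therefore expected to give about 6500 nM in this assay, with a range from 3000 nM to 14000 nM. This estimate corresponds to an expected step of a 1.5-fold higher number from compound 1 to compound 4 (0.17 log units; within the scatter).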

Compound 4, half-maximal inhibitory concentration: 5670 nM
Estimate against measurement, compound 4: 1.1-fold (0.06 log units) above; the range from low to high includes it.
By their numbers in this assay, from the lowest: compounds 1, 3, 4 and 2 (each within the scatter of the next, the first and the last beyond it).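

In this assay the steps of a 1.3-fold higher number from compound 1 to compound 4 (0.11 log units; within the scatter) and a 1.2-fold higher number from compound 3 to compound 4 (0.07 log units; within the scatter) and a 1.6-fold lower number from compound 2 to compound 4 (0.21 log units; within the scatter) all lie within the scatter, so compound 4 stands apart from none of the three earlier amides. Among the compounds shown here, a ring on the carbonyl carbon and the loss of the amide hydrogen therefore do not on their own give a step beyond the scatter from compound 1: compound 4 has both and stays within it, while compound 2, which also has both, remains the only compound separated from compound 1, by a 2.1-fold higher number from compound 1 to compound 2 (0.32 log units; beyond the scatter). No measurement shown bears on what lies behind these numbers.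

Still open, on these data alone, is whether the separation of compound 2 from compound 1 belongs to its phenyl group or to its ring: a 4-methylpiperidin-1-yl amide would keep a ring without the second ring nitrogen, and a 4-phenylpiperazin-1-yl amide would put the phenyl group on the ring of compound 4. Also open, as far as these compounds go, is whether the amide itself matters on this chain, which a carboxylic acid in its place would address.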